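Swapping a basic chain for a tolyl group

A few compounds are considered here, and "the series" means these few. Any claim that something is new, unique, unknown or untested is made for them only; others in the source may bear on it.

Compound 1 `CC1CCN(CCCSc2nc(C(F)(F)F)ccc2CNC(=O)C(C)c2ccc(NS(C)(=O)=O)c(F)c2)CC1` gives 2.9 nM. Compound 2 `CC(C(=O)NCc1ccc(C(F)(F)F)nc1SCc1ccc(Cl)cc1)c1ccc(NS(C)(=O)=O)c(F)c1` gives 8.7 nM.

In an assay on CHO-K1 cells for antagonist activity at transient receptor potential cation channel subfamily V member 1 (Homo sapiens), read by FLIPR (a lower number here means a stronger inhibitor, a higher number a weaker inhibitor), compound 1 stands with the lower of the two numbers. Compound 3 `Cc1ccc(CSc2nc(C(F)(F)F)ccc2CNC(=O)C(C)c2ccc(NS(C)(=O)=O)c(F)c2)cc1` differs from compound 1 by 4-methylphenyl in place of 2-(4-methylpiperidin-1-yl)ethyl on a saturated chain carbon bound to a sulfur. Going by the values given here, the one measured step that bears on this is a 3.0-fold higher number from compound 1 to compound 2 (0.48 log units; beyond the scatter), where a 4-chlorophenyl also replaced the same chain. A step of similar size and direction is therefore expected in this assay for compound 3, giving a 2.8-fold higher number from compound 1 to compound 3 (0.44 log units; beyond the scatter). Compound 3 is thus estimated at 8 nM, with a likely range from 3 nM to 25 nM.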

Compound 3, inhibition constant: 3.2 nM
Beside the measured number, compound 3's estimate is 2.5-fold (0.40 log units) above it, and the stated range covers the measured number.
By their numbers in this assay, from the lowest: compounds 1 and 3 (each within the scatter of the next); then compound 2.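

Across this position, a large change of group can leave the number in this assay almost untouched, as a 1.1-fold higher number from compound 1 to compound 3 (0.04 log units; within the scatter) shows, so the ring nitrogen of the 2-(4-methylpiperidin-1-yl)ethyl chain is not needed to keep it this low. A much smaller change on the aromatic ring, methyl in place of chloro, matters more, giving a 2.7-fold lower number from compound 2 to compound 3 (0.43 log units; beyond the scatter). Nothing measured here explains either result.

Still open, as far as these compounds go, is how a methoxy group or a carboxylic acid on that ring carbon would compare with methyl and chloro. A simple primary amine at the end of the chain is also untested among the compounds shown.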